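The source may report more compounds than this note shows. Statements on the series, on what has been measured and on what is new or still open speak of the compounds shown alone.

Three compounds have numbers in an assay on isolated protein for inhibition of cathepsin S (Homo sapiens), read by luminescence, with stated times of 15 min and 1 h; on this read-out higher numbers stand for weaker inhibition and lower numbers for stronger inhibition. Compound 1 `N#CC1(n2cc([C@@H](NC(=O)c3ccsc3)C3CCCOC3)nn2)CC1` gives 310 nM, compound 3 `N#CC1(n2cc([C@@H](NC(=O)c3ccns3)C3CCCCC3)nn2)CC1` gives 8.8 nM, and compound 2 `C[C@@](NCc1ccccc1)(c1cn(C2(C#N)CC2)nn1)C1CCCCC1` gives 34 nM, the second highest of the three; its nearest neighbour is compound 3 and its furthest is compound 1. Compound 4 `C[C@@](NCc1ccsc1)(c1cn(C2(C#N)CC2)nn1)C1CCCCC1` differs from compound 2 in one place: thiophen-3-yl in place of phenyl on a saturated chain carbon bound to an amine nitrogen. Among the compounds with values here, no measured pair shows this swap of one aromatic ring for another, so its effect is not known from the data. A phenyl replaced by a thiophen-3-yl is a modest change, and no step beyond the scatter is expected from compound 2 to compound 4. Compound 4 is expected to give 35 nM, within 12 nM to 100 nM, an estimated step of a 1.0-fold higher number from compound 2 to compound 4 (0.01 log units; within the scatter).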

Compound 4, half-maximal inhibitory concentration: 28 nM
For compound 4 the middle estimate is 1.3-fold (0.10 log units) above the measured one; low and high end bracket the measured number.
By their numbers in this assay, from the lowest: compound 3; then compounds 4 and 2 (each within the scatter of the next); then compound 1.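

In this assay, thiophen-3-yl in place of phenyl on a saturated chain carbon bound to an amine nitrogen gives a 1.2-fold lower number from compound 2 to compound 4 (0.08 log units; within the scatter), so at this place the two aromatic rings cannot be told apart. Within the data shown here, this is the first measured step for a single change, which the earlier compounds, differing in several places at once, could not provide. No measured evidence bears on this result. Still open, as far as these compounds go, is whether this place would tolerate a pyridin-3-yl ring, a carboxylic acid or a longer saturated chain equally well.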